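The source may hold more compounds than are shown below. What is called first, only, known or untested is meant among the compounds shown, and "the series" means these compounds.

Measured in an ADME assay on MT2 cells (Homo sapiens) for cytotoxicity, read by XTT assay, with a stated time of 4 days; a higher number here means that more compound is tolerated, a lower number that less compound is tolerated:
Compound 1 `Cc1ccc(NC(=O)C(=O)NC(c2nc(C)c(CCO)s2)C2CCCCN2)cc1F`: 85000 nM
Compound 2 `Cc1nc(C(NC(=O)C(=O)Nc2ccc(F)cc2)C2CCCCN2)sc1CCO`: 109000 nM
Compound 3 `Cc1nc(C(NC(=O)C(=O)NC2CCCCCC2)C2CCCCN2)sc1CCO`: 60000 nM

Compound 3 lies within the usual scatter of both other compounds, so these numbers set no order among the three. Compound 4 `Cc1nc(C(NC(=O)C(=O)Nc2ccc(Cl)cc2)C2CCCCN2)sc1CCO` differs from compound 3 in one place: 4-chlorophenyl in place of cycloheptyl on an amide-type nitrogen. Two measured steps made the reverse kind of exchange, putting cycloheptyl in place of a phenyl group: a 1.4-fold lower number from compound 1 to compound 3 (0.15 log units; within the scatter) and a 1.8-fold lower number from compound 2 to compound 3 (0.26 log units; within the scatter). Exchanging one phenyl group for another gave a 1.3-fold higher number from compound 1 to compound 2 (0.11 log units; within the scatter). All three steps stay within the scatter, so no step beyond the scatter is expected here. The estimated step is a 1.5-fold higher number from compound 3 to compound 4 (0.18 log units; within the scatter). For compound 4 the expected value is 90000 nM, with an estimated range from 45000 nM to 170000 nM.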

Compound 4, half-maximal cytotoxic concentration: > 62000 nM
Compound 4 gave a limit, no number; the forecaster's own chance of this, stated with the estimate: 15%; the middle value does not contradict the limit.
By their numbers in this assay, from the lowest: compounds 3, 1 and 2 (each within the scatter of the next).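

In this assay compound 4 gives a limit of the assay, not a number: the limit of > 62000 nM in this assay, at which 1 of the 4 values shown sits.
So chlorine enters this position for the first time, as 4-chlorophenyl on the amide-type nitrogen, and the only readable comparison is a floor (an at least 1.0-fold higher number from compound 3 to compound 4 (0.01 log units; that floor lies within the scatter)). This change therefore gives no sign of a separation from the cycloheptyl compound, and the steps from compound 1 and compound 2 to compound 4 cannot be read. Still open, on these data alone, is how a group carrying an amine or a carboxylic acid at this nitrogen would read in this assay. As far as these compounds go, the size of the step to compound 4 also remains open without a number in place of the limit.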